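The source may hold more compounds than are shown below. What is called first, only, known or untested is meant among the compounds shown, and "the series" means these compounds.

Measured so far:
- Compound 1, `O=S(=O)(c1ccc(F)c(Cl)c1)c1cnc2c(F)cccc2c1-c1cccc(Cl)c1`: 0.18 mL/min
- Compound 2, `Cc1ccc(S(=O)(=O)c2cnc3c(F)cccc3c2-c2cccc(F)c2)cc1F`: 3.92 mL/min

In an ADME assay on microsomes from liver (Homo sapiens) for metabolic stability, tested at 2.5 uM (a lower number here means slower removal, a higher number faster removal of the compound), compound 2 gives the higher of the two numbers; compound 1 sits far lower, and the gap lies beyond the usual scatter. Among the compounds with values here, the two structures differ at more than one place, so no single step is drawn between them.

Compound 3, `Cc1ccc(S(=O)(=O)c2cnc3c(F)cccc3c2-c2cccc(Cl)c2)cc1F`, is not yet measured. It differs from compound 2 by chloro in place of fluoro on an aromatic carbon. Within the data shown here, with only two measured compounds and no isolated step for this exchange, the expected step of a 1.5-fold lower number from compound 2 to compound 3 (0.18 log units; within the scatter) is small, downward at most, and may stay within the scatter. Compound 3 is estimated at 2.6 mL/min, range 1 mL/min to 6 mL/min.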

Compound 3, intrinsic clearance in a liver preparation (reported as CLH), per the amount of preparation that the assay uses: 3.18 mL/min
For compound 3 the middle estimate is 1.2-fold (0.09 log units) below the measured one, and the stated range covers the measured number.
By their numbers in this assay, from the lowest: compound 1; then compounds 3 and 2 (each within the scatter of the next).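

In this assay, the exchange of 3-fluorophenyl for 3-chlorophenyl gives a 1.2-fold lower number from compound 2 to compound 3 (0.09 log units; within the scatter), so chloro and fluoro are not told apart at this position on this background. With the 3-chlorophenyl held fixed, the change on the sulfonyl sulfur gives an 18-fold higher number from compound 1 to compound 3 (1.25 log units; beyond the scatter), which places the large difference among these compounds on the sulfonyl side. Nothing available bears on the reason for either step. From the compounds shown here alone, it remains open whether the methyl or the exchanged halogen on the sulfonyl-bound ring carries the large step. Going by these compounds, how a methoxy group or an amine would behave in place of the chloro also remains open.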